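The source may report more compounds than this note shows. Statements on the series, on what has been measured and on what is new or still open speak of the compounds shown alone.

Measured compounds:
- compound 1, `COc1ccc2c(c1)c(CCCC(=O)N1CCOCC1)c(C)n2Cc1ccccc1`, in an assay on cells for inhibition of Polyunsaturated fatty acid 5-lipoxygenase (Rattus norvegicus), tested at 5 uM (on this read-out lower numbers stand for less inhibition and higher numbers for more inhibition at the one concentration tested (going by the name of the read-out)), compound 1 gives 54.2%
- compound 2, `COc1ccc2[nH]c(C)c(CCCC(=O)N3CCN(C(=O)OC(C)(C)C)CC3)c2c1`, in this assay compound 2 gives 71.2%
- compound 3, `COc1ccc2c(c1)c(CCCC(=O)N1CCN(C(=O)OC(C)(C)C)CC1)c(C)n2Cc1ccccc1`, in this assay compound 3 gives 51.5%

Compound 3 holds the lowest of the three numbers, yet its gap to compound 1 lies within the scatter, so the two cannot be ranked; only compound 2 stands clearly apart, the change being a number 19.7 percentage points lower from compound 2 to compound 3 (beyond the scatter).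

Compound 4, `COc1ccc2c(c1)c(CCCC(=O)N1CCNCC1)c(C)n2Cc1ccccc1`, is the counterpart of compound 3 with one difference: hydrogen in place of tert-butoxycarbonyl on an amine nitrogen in a ring. Within the data shown here, no measured pair among the three compounds differs in this group, so none of the known steps speaks to it; the single measured step concerns the aromatic nitrogen, not the amine nitrogen in the ring. With nothing in the data pointing either way, the expectation for this assay is a step from compound 3 to compound 4 of no size beyond the scatter, that is a number 0.5 percentage points higher from compound 3 to compound 4 (within the scatter). Compound 4 is therefore estimated at 52%, with a range from 30% to 74%.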

Compound 4, a percentage reported as inhibition, at one concentration (the size of the read-out at that concentration, not a potency): 64.6%
Compound 4: the middle estimate sits 12.6 percentage points below what was measured; the measured number falls inside the stated range.
By their numbers in this assay, from the lowest: compounds 3 and 1 (each within the scatter of the next); then compounds 4 and 2 (each within the scatter of the next).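

In this assay, the amine nitrogen in the ring proves to be a place where the group matters: hydrogen in place of tert-butoxycarbonyl gives a number 13.1 percentage points higher from compound 3 to compound 4 (beyond the scatter) and so the large group is not needed for this level of inhibition. The ring itself also counts, as piperazin-1-yl in place of morpholin-4-yl on the carbonyl carbon gives a number 10.4 percentage points higher from compound 1 to compound 4 (beyond the scatter) and thus a free ring amine reads better here than the ring oxygen of the morpholine. Nothing available explains either step.

Going by these compounds, whether a small group on that ring nitrogen, such as methyl or acetyl, would give a number closer to that of the hydrogen or to that of tert-butoxycarbonyl stays open. Also open, on these data alone, is how a shorter or longer chain between the shared core and the carbonyl would read.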